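Trifluoromethyl for hydroxy on the pendant phenyl ring

The compounds below may be only part of what the source reports. "The series", "measured", "known", "first", "only" and "open" are said of these compounds alone.

Measured compounds:
compound 1, `CCCS(=O)(=O)Nc1ccc(F)c(C(=O)c2n[nH]c3ncc(-c4ccc(F)cc4)cc23)c1F`: 2.1%
compound 2, `CCCS(=O)(=O)Nc1ccc(F)c(C(=O)c2n[nH]c3ncc(-c4cccc(OC)c4)cc23)c1F`: 6.3%
compound 3, `CCCS(=O)(=O)Nc1ccc(F)c(C(=O)c2n[nH]c3ncc(-c4cccc(O)c4)cc23)c1F`: 2.2%

In an assay for binding affinity to dual specificity mitogen-activated protein kinase kinase 4 (Homo sapiens), read by KINOMEscan, tested at 100 nM (on this read-out lower numbers stand for a stronger effect and higher numbers for a weaker effect at the one concentration tested), compound 3 gives 2.2%, and it lies within the scatter of both neighbours: a number 0.1 percentage points higher from compound 1 to compound 3 (within the scatter) and a number 4.1 percentage points lower from compound 2 to compound 3 (within the scatter). Compound 4, `CCCS(=O)(=O)Nc1ccc(F)c(C(=O)c2n[nH]c3ncc(-c4cccc(C(F)(F)F)c4)cc23)c1F`, differs from compound 3 by one change: trifluoromethyl in place of hydroxy on an aromatic carbon.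

Going by the values given here, the steps that bear on this change are those that alter the same phenyl ring, a number 4.2 percentage points higher from compound 1 to compound 2 (within the scatter), a number 0.1 percentage points higher from compound 1 to compound 3 (within the scatter) and a number 4.1 percentage points lower from compound 2 to compound 3 (within the scatter), all within the scatter. Nothing measured shows a trifluoromethyl at this place, so the expectation rests on these three steps and on compound 3 with 2.2%. Compound 4 is therefore expected to show a step of a number 1.8 percentage points higher from compound 3 to compound 4 (within the scatter), not beyond the scatter. The estimate for compound 4 in this assay is 4%, ranging from 1% to 15%.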

Compound 4, a percentage reported as activity, at one concentration (the size of the read-out at that concentration, not a potency): 57%
Compound 4: middle estimate off by 53 percentage points, on the low side; measured number above the stated range.
By their numbers in this assay, from the lowest: compounds 1, 3 and 2 (each within the scatter of the next); then compound 4.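

In this assay this place on the pendant phenyl ring proves sensitive to the group it carries, with trifluoromethyl giving a number 54.8 percentage points higher from compound 3 to compound 4 (beyond the scatter) and a number 50.7 percentage points higher from compound 2 to compound 4 (beyond the scatter) and also a number 54.9 percentage points higher from compound 1 to compound 4 (beyond the scatter) in the comparison with the 4-fluorophenyl compound. Hydroxy and methoxy had stayed within the scatter of each other, so the compounds before gave no sign of this limit. No evidence given here accounts for the step. Still open, from the compounds shown here alone, is whether a methyl, a chlorine, a nitrile or an amine at this place would stay close to compound 3 or fall towards compound 4.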